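The source may hold more compounds than are shown below. What is called first, only, known or untested is meant among the compounds shown, and "the series" means these compounds.

Measured compounds:
compound 1, `CCCCCCCC/C=C\CCCCCCCC[Se]C[C@H](N)C(=O)NCc1ccc(O)c(OC)c1`, 980 nM in an assay on HEK293 cells for antagonist activity at transient receptor potential cation channel subfamily V member 2 (Rattus norvegicus), read by fluorescence and calcium flux, with a stated time of 5 min; on this read-out lower numbers stand for stronger inhibition and higher numbers for weaker inhibition
compound 2, `CCCCCCCC/C=C\CCCCCCCCSC[C@H](N)C(=O)NCc1ccc(O)c(OC)c1`, "not determined" (no result reported) in this assay
compound 3, `CCCCCC[C@@H](O)C/C=C\CCCCCCCCSCCC(=O)NCc1ccc(O)c(OC)c1`, "not determined" (no result reported) in this assay

For the measured compounds named here, compound 1 is the only compound of the three with a number in this assay; for compound 1 that number is 980 nM, and compounds 2 and 3 give nothing against which it could be set. Compound 1 therefore stands alone, neither strong nor weak relative to anything shown.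

Compound 4, `CCCCCCCC/C=C\CCCCCCCC[Se]CCC(=O)NCc1ccc(O)c(OC)c1`, keeps the chain, the selenium link and the amide to the shared core of compound 1 and differs from it in one place: hydrogen in place of amino on a saturated chain carbon bound to a carbonyl carbon and a saturated chain carbon. Going by the values given here, no pair of measured compounds shows what such a change does in this assay, so the size and direction of the step are open. Compound 4 is expected to give 1600 nM, within 500 nM to 5000 nM. The step from compound 1 to compound 4 is thus estimated at a 1.6-fold higher number from compound 1 to compound 4 (0.21 log units; within the scatter), toward weaker inhibition, at the edge of the usual scatter.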

Compound 4, half-maximal inhibitory concentration: 3200 nM
Beside the measured number, compound 4's estimate is 2.0-fold (0.30 log units) below it, within the range that was stated.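

Putting hydrogen in place of amino on a saturated chain carbon bound to a carbonyl carbon and a saturated chain carbon gives, in this assay, a 3.3-fold higher number from compound 1 to compound 4 (0.51 log units; beyond the scatter), which means weaker inhibition once the amino group is gone. For the compounds shown here, this is the first readable step at this position, and it shows that, with the chain, the selenium link and the amide held constant, the amino group's presence matters to this read-out, though the shift is modest. The data shown offer nothing that explains this shift.

From the compounds shown here alone, the steps involving compound 2 and compound 3 cannot be read, so the effect of a sulfur link in place of the selenium link stays open. Also open, going by these compounds, is how a methyl group, a hydroxyl group or a dimethylamino group on the same carbon would compare with amino and hydrogen.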